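The compounds below may be only part of what the source reports. "The series", "measured", "known", "first", "only" and "open" are said of these compounds alone.

Working notes on the series.

Compound 1, `C/C(=N\O)c1ccc2[nH]c(-c3ccc(Cl)cc3)nc2c1`, and compound 2, `C/C(=N\O)c1ccc2[nH]c(-c3ccc(C(F)(F)F)cc3)nc2c1`, share a core and differ only in one place: trifluoromethyl in place of chloro on an aromatic carbon. In an ADME assay on MDBK cells (Bos taurus) for cytotoxicity, read by MTT assay, with a stated time of 96 h (on this read-out lower numbers stand for higher toxicity in this test and higher numbers for lower toxicity in this test), compound 1 gives 37000 nM. In this assay compound 2 gives 55000 nM. The step is a 1.5-fold higher number from compound 1 to compound 2 (0.17 log units; within the scatter), so the two values are not told apart by this test.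

Compound 3, `CC(=O)c1ccc2c(c1)nc(-c1ccc(Cl)cc1)n2C1CCCCC1`, carries a different core; the difference between the two cores is not broken down here. In this assay compound 3 reaches only a limit of the test, > 100000 nM. That limit, (the limit of > 100000 nM in this assay, at which 1 of the 3 values shown sits), is where one of the three measured values sits, so for compound 3 no number is known, only that it is not more toxic than the limit allows.

Compound 4, `CC(=O)c1ccc2c(c1)nc(-c1ccc(C(F)(F)F)cc1)n2C1CCCCC1`, has not yet been measured. It stands to compound 3 as compound 2 stands to compound 1: trifluoromethyl in place of chloro on an aromatic carbon. The change is the same one, at the same place. The step expected in this assay is a number no higher from compound 3 to compound 4 (the limit leaves the size open), which rests on compound 1 and compound 2, where the same change gave a 1.5-fold higher number from compound 1 to compound 2 (0.17 log units; within the scatter). With compound 3 already at a limit, compound 4 is expected to sit at or near that limit as well, estimated at 100000 nM, with a range of 50000 nM to 200000 nM; most likely the test will again report only a limit rather than a number.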

Compound 4, half-maximal cytotoxic concentration: 52000 nM
Beside the measured number, compound 4's estimate is 1.9-fold (0.28 log units) above it, within the range that was stated.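

In this assay, the exchange of chloro for trifluoromethyl on the core of compound 3 gives an at least 1.9-fold lower number from compound 3 to compound 4 (0.28 log units; that floor lies within the scatter), and this step does not match the one seen on the core of compound 1, so within these two pairs the size of the change does not carry from one core to the other: the same change on two cores in this assay, a 1.5-fold higher number (0.17 log units; within the scatter) from compound 1 to compound 2 and an at least 1.9-fold lower number (0.28 log units; that floor lies within the scatter) from compound 3 to compound 4, at least 2.8-fold (0.45 log units) apart, beyond the scatter of two such steps

For compound 3 the test gives only a limit, > 100000 nM, and not a number: the limit of > 100000 nM in this assay, at which 1 of the 4 values shown sits.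

This shows a dependence on the core for a single change in a single test, resting on one pair per core, but it does not show which of the differences between the two cores goes with the gap, nor does it show how far the step on the core of compound 3 truly extends.

What the compounds shown leave open is whether the gap would persist with the oxime kept and a cyclohexyl group added, or with the acetyl kept and the ring nitrogen left free, each tested with chloro and trifluoromethyl. Also open, as far as these compounds go, is how a nitrile, an amine or a carboxylic acid on the same aromatic carbon would read in this assay on either core.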